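A few compounds are considered here, and "the series" means these few. Any claim that something is new, unique, unknown or untested is made for them only; others in the source may bear on it.

Of the compounds shown here, three on the shared core have been measured so far: compound 1 (`C[C@H](NC(=O)C(=O)NCCC1CCCC1)C(=O)N[C@@H](CC(=O)O)C(=O)COc1c(F)c(F)cc(F)c1F`), compound 2 (`C[C@H](NC(=O)C(=O)NCC1CCCCC1)C(=O)N[C@@H](CC(=O)O)C(=O)COc1c(F)c(F)cc(F)c1F`) and compound 3 (`C[C@H](NC(=O)C(=O)NCC1(c2ccccc2)CC1)C(=O)N[C@@H](CC(=O)O)C(=O)COc1c(F)c(F)cc(F)c1F`). In a functional assay on Jurkat cells (Homo sapiens) (on this read-out lower numbers stand for stronger inhibition and higher numbers for weaker inhibition), compound 1 gives 11 nM, compound 2 gives 19 nM and compound 3 gives 27 nM. Compound 3 cannot be separated from compound 2, with a 1.4-fold higher number from compound 2 to compound 3 (0.15 log units; within the scatter), but it does stand apart from compound 1, with a 2.5-fold higher number from compound 1 to compound 3 (0.39 log units; beyond the scatter).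

Next is compound 4 (`C[C@H](NC(=O)C(=O)NCc1ccccc1F)C(=O)N[C@@H](CC(=O)O)C(=O)COc1c(F)c(F)cc(F)c1F`), with this change: 2-fluorophenyl in place of 1-phenylcyclopropyl on a saturated chain carbon bound to an amide-type nitrogen. In words, 2-fluorophenyl replaces 1-phenylcyclopropyl on a saturated chain carbon bound to an amide-type nitrogen.

All measured steps fall at this same place. Besides the two above, there is a 1.7-fold higher number from compound 1 to compound 2 (0.24 log units; within the scatter). Going by the values given here, the largest of the three, the step to compound 3 from compound 1, is only modest, and no measured compound carries 2-fluorophenyl. With so few compounds, the steps give no direction for this change. The expectation in this assay is therefore a step no larger than the modest one seen so far, and probably none beyond the scatter. The estimated change is a 1.4-fold lower number from compound 3 to compound 4 (0.13 log units; within the scatter). Compound 4 is expected at 20 nM, with an estimated range of 8 nM to 55 nM.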

Compound 4, half-maximal inhibitory concentration: 207 nM
Estimate against measurement, compound 4: 10-fold (1.01 log units) below, and the stated range ends below it.
By their numbers in this assay, from the lowest: compounds 1, 2 and 3 (each within the scatter of the next, the first and the last beyond it); then compound 4.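

Up to compound 3 this position looked tolerant, but in this assay the swap to 2-fluorophenyl shows that it is not, with a 7.7-fold higher number from compound 3 to compound 4 (0.88 log units; beyond the scatter), an 11-fold higher number from compound 2 to compound 4 (1.04 log units; beyond the scatter) and a 19-fold higher number from compound 1 to compound 4 (1.27 log units; beyond the scatter). Going by these compounds alone, the position therefore does not accept every group of similar size, and a six-membered aromatic ring of carbon only does not settle the outcome by itself: compound 3 carries such a ring within its 1-phenylcyclopropyl group and stays with the earlier compounds, whereas compound 4 carries one and stands apart from all three. Nothing available here explains why the number rises at this place.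

The compounds shown leave open whether the rise goes with the fluorine of the 2-fluorobenzyl group or with the benzyl group itself, a question that plain benzyl at the same place would address. Also open, going by these compounds, is whether a longer chain, such as 2-phenylethyl, or a 1-phenylcyclopropyl group carrying fluorine on its aromatic ring, would stay with compounds 1, 2 and 3 or move towards compound 4.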